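This account rests on a few compounds, and the source may have more. Where it says the series, first, only, none or still open, it means among the compounds named here.

Measured compounds:
Compound 1 `COc1ccccc1-c1nnc(SCCn2c([N+](=O)[O-])cnc2C)o1`: in a functional assay on HepG2 cells (Homo sapiens) for cytotoxicity, read by MTT assay, with a stated time of 48 h (a higher number here means a weaker inhibitor, a lower number a stronger inhibitor), compound 1 gives 10000 nM.
Compound 2 `CCOc1ccc(-c2nnc(SCCn3c([N+](=O)[O-])cnc3C)o2)cc1`: in this assay compound 2 gives 1900 nM.
Compound 3 `Cc1ncc([N+](=O)[O-])n1CCSc1nnc(-c2ccc([N+](=O)[O-])cc2)o1`: in this assay compound 3 gives 4100 nM.

Compound 1 stands at the highest number of the three in this assay; compound 3 lies nearest to it and compound 2 furthest, both gaps beyond the scatter. Among the compounds with values here, the only single-place step so far is a 2.2-fold higher number from compound 2 to compound 3 (0.33 log units; beyond the scatter). Compound 4 `Cc1ncc([N+](=O)[O-])n1CCSc1nnc(-c2cccnc2)o1` differs from compound 1 as follows: pyridin-3-yl in place of 2-methoxyphenyl on an aromatic carbon. Within the data shown here, no measured step swaps the whole aryl group on the shared core, so the step from compound 2 to compound 3 bears on it only loosely. The series spans a narrow band, and compounds 2 and 3 lie at lower numbers than compound 1. Compound 4 is therefore expected to stay near that highest number, with a drift toward the lower numbers taken as the estimated step of a 1.7-fold lower number from compound 1 to compound 4 (0.22 log units; within the scatter). Compound 4 is thus estimated at 6000 nM, with a range from 2500 nM to 15000 nM.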

Compound 4, half-maximal inhibitory concentration: 9600 nM
For compound 4 the middle estimate is 1.6-fold (0.20 log units) below the measured one; the measured number falls inside the stated range.
By their numbers in this assay, from the lowest: compound 2; then compound 3; then compounds 4 and 1 (each within the scatter of the next).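

In this assay, the change from 2-methoxyphenyl to pyridin-3-yl on the aromatic carbon of the shared core gives a 1.0-fold lower number from compound 1 to compound 4 (0.02 log units; within the scatter). Within the data shown here, this is the first direct reading of a whole aryl swap here, and a ring of carbon only and a ring with one hetero atom cannot be told apart in this assay. No measurement at hand accounts for this. Still open, from the compounds shown here alone, is whether a pyridine bearing an amine or a carboxylic acid, or a saturated ring such as piperidine, would shift the number at this position.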